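The source may report more compounds than this note shows. Statements on the series, on what has been measured and on what is new or still open speak of the compounds shown alone.

Working notes on the series. Compound 1 `C/C(=N\CC(C)C)c1c(O)c2ccccc2oc1=O` and compound 3 `C/C(=N\CCO)c1c(O)c2ccccc2oc1=O` share one core; in an assay on isolated protein for inhibition of myosin-2 (Bos taurus), read by spectrophotometry, with a stated time of 24 min (a higher number here means a weaker inhibitor, a lower number a stronger inhibitor), compound 1 gives 34000 nM, and compound 3 gives 92000 nM. For the measured compounds named here, the only measured step, a 2.7-fold higher number from compound 1 to compound 3 (0.43 log units; beyond the scatter), is the change of the side chain on a saturated carbon bound to the double-bonded nitrogen. Compound 2 `C/C(=N\C(C)C)c1c(O)c2ccccc2[nH]c1=O` carries a different core. For compound 2 this assay reports only a limit, >= 100000 nM, and not a number. Compound 2 thus stands at the edge of the range shown (the limit of >= 100000 nM in this assay, at which 1 of the 3 values shown sits). Compound 4 `CCC/N=C(\C)c1c(O)c2ccccc2[nH]c1=O` has the same atoms as compound 2, joined differently: propyl in place of isopropyl on a double-bonded nitrogen. Going by the values given here, no measured step covers a change of this kind; the step from compound 1 to compound 3 swaps in a hydroxyl-bearing chain and was modest, so it bears only loosely here. The expected step that the limit leaves unreadable from compound 2 to compound 4 is none beyond the scatter. Compound 4 is estimated at 150000 nM, in a range from 50000 nM to 450000 nM, most probably reported again as a limit.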

Compound 4, half-maximal inhibitory concentration: >= 100000 nM
Compound 4: a limit, no number; the forecaster's own chance of this, stated with the estimate: 75%; the middle value is on the limit's open side.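

In this assay compound 4 gives >= 100000 nM as a limit and not a number. For the compounds shown here, compound 2 is also reported only as a limit, and no step between compound 2 and compound 4 can be read. The compounds shown leave open whether propyl in place of isopropyl on a double-bonded nitrogen changes the inhibition at all.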